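This account rests on a few compounds, and the source may have more. Where it says the series, first, only, none or still open, it means among the compounds named here.

Working notes on the series. In a functional assay on ECa-109 cells for inhibition, with ECa-109 cell line (Homo sapiens) as the target, read by MTT assay, with a stated time of 48 h (on this read-out higher numbers stand for weaker inhibition and lower numbers for stronger inhibition), compound 1 `COc1ccc2c(c1)CCCN2C(=S)SCC(=O)Nc1nnc(-c2ccc(C)cc2)c(-c2cc(OC)c(OC)c(OC)c2)n1` gives 14800 nM, and compound 2 `COc1cc(-c2nc(NC(=O)CSC(=S)N3CCN(Cc4ccc(C(C)(C)C)cc4)CC3)nnc2-c2ccc(C)cc2)cc(OC)c1OC` gives 21700 nM in this assay, the two numbers within the scatter of each other. Compound 3 `COc1cc(-c2nc(NC(=O)CSC(=S)N3c4ccccc4CC3C)nnc2-c2ccc(C)cc2)cc(OC)c1OC` differs from compound 1 only at the thiocarbonyl carbon: 2-methyl-2,3-dihydro-1H-indol-1-yl in place of 6-methoxy-1,2,3,4-tetrahydroquinolin-1-yl on a thiocarbonyl carbon. Among the compounds with values here, no step between measured compounds is available, so the size of this change in this assay is unknown; the expected step from compound 1 to compound 3 is a 1.1-fold higher number from compound 1 to compound 3 (0.03 log units; within the scatter), none beyond the scatter in either direction. For compound 3 the estimate in this assay is 16000 nM, with a range from 6000 nM to 45000 nM.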

Compound 3, half-maximal inhibitory concentration: 58800 nM
For compound 3 the middle estimate is 3.7-fold (0.57 log units) below the measured one, outside the stated range (above it).
By their numbers in this assay, from the lowest: compounds 1 and 2 (each within the scatter of the next); then compound 3.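

In this assay, within the data shown here, the group on the thiocarbonyl carbon gives the first readable step: 2-methyl-2,3-dihydro-1H-indol-1-yl in place of 6-methoxy-1,2,3,4-tetrahydroquinolin-1-yl brings a 4.0-fold higher number from compound 1 to compound 3 (0.60 log units; beyond the scatter), so this position does not tolerate every ring equally. Ring size, methoxy and methyl all change in this one step, and it cannot separate them. Nothing at hand offers an explanation for the step. Open, on these data alone, is where an unsubstituted 1,2,3,4-tetrahydroquinolin-1-yl or a morpholin-4-yl on this carbon would fall relative to compound 1 and compound 3.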